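Swapping the Amide Substituent: From Aryl to Acyl Hydrazide

A few compounds are considered here, and "the series" means these few. Any claim that something is new, unique, unknown or untested is made for them only; others in the source may bear on it.

Measured so far:
compound 1 `Cc1cc(C)cc(NC(=O)COc2cc(C)nc3ccc(C)cc23)c1` gives 5.95
compound 2 `COc1ccc2nc(C)cc(OCC(=O)Nc3c(C)cccc3C)c2c1` gives 4.55

Of the two numbers in a physicochemical assay for lipophilicity, read by HPLC, in phosphate buffer, measured as chromatographic lipophilicity, at pH 7.4 (a higher number here means a more lipophilic compound, a lower number a more polar compound), compound 2 holds the lower one, and its gap to compound 1 lies beyond the usual scatter. Compound 3 `COc1ccc2nc(C)cc(OCC(=O)NNC(=O)c3ccncc3)c2c1` has not been measured. It differs from compound 2 in one place: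

((pyridin-4-yl)carbonyl)amino in place of 2,6-dimethylphenyl on an amide-type nitrogen

Among the compounds with values here, with no measured pair showing this change, the expected step from compound 2 to compound 3 is a number 2.75 log units lower from compound 2 to compound 3 (beyond the scatter), a fall well beyond the scatter. For compound 3 the expected value in this assay is 1.8, with a likely range from 1 to 2.8.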

Compound 3, distribution coefficient: 1.48
Beside the measured number, compound 3's estimate is 0.32 log units above it; low and high end bracket the measured number.
By their numbers in this assay, from the lowest: compound 3; then compound 2; then compound 1.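

In this assay the group on this amide-type nitrogen matters strongly: ((pyridin-4-yl)carbonyl)amino in place of 2,6-dimethylphenyl gives a number 3.07 log units lower from compound 2 to compound 3 (beyond the scatter) with the rest of the molecule unchanged. The entering group brings a hydrogen-bond donor and hydrogen-bond acceptors, which the leaving group lacks. Nothing available explains the size of this step. Within the data shown here, the single swap changes the ring and adds the carbonyl and amino link together, so their separate shares remain open. As far as these compounds go, how a benzoylamino group, with a ring of carbon only, would read on this nitrogen also remains open.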